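Compound 3 to compound 4: exchanging a dimethoxyphenyl group

The compounds below may be only part of what the source reports. "The series", "measured", "known", "first", "only" and "open" are said of these compounds alone.

Results so far in a functional assay on HepG2 cells (Homo sapiens) for cytotoxicity, read by sulforhodamine B assay, with a stated time of 48 h (on this read-out higher numbers stand for weaker inhibition and lower numbers for stronger inhibition), are as follows
compound 1 `COc1ccc(/C=C/C(=O)c2ccc(N)c(-c3ccc(F)cc3)c2)cc1O` – "not determined" (no result reported)
compound 2 `COc1ccc(/C=C/C(=O)c2ccc(NC(C)=O)c(-c3ccc(F)cc3)c2)cc1OC` – 5630 nM
compound 3 `COc1ccc(-c2cc(C(=O)/C=C/c3cccc(OC)c3OC)ccc2N)cc1OC` – 5360 nM

Only two of these compounds carry a number. Compound 3 (5360 nM) and compound 2 (5630 nM) lie within the usual scatter of each other, so the data set no order between them. Compound 1 has no reported result.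

The next compound is compound 4 `COc1ccc(/C=C/C(=O)c2ccc(N)c(-c3ccc(OC)c(OC)c3)c2)c(OC)c1`, in which 2,4-dimethoxyphenyl replaces 2,3-dimethoxyphenyl on a double-bonded chain carbon bound to a double-bonded chain carbon (2,4-dimethoxyphenyl in place of 2,3-dimethoxyphenyl on a double-bonded chain carbon bound to a double-bonded chain carbon). Within the data shown here, no pair of measured compounds differs in one place, so the data offer no direct guide to this exchange. The expectation therefore starts from compound 3 at 5360 nM and the matching counts of the two groups. In this assay no step beyond the scatter is expected. The estimated step is a 1.1-fold lower number from compound 3 to compound 4 (0.03 log units; within the scatter) and it is expected to stay within the scatter. Compound 4 is estimated at 5000 nM with a range from 2000 nM to 12000 nM expected for it.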

Compound 4, half-maximal inhibitory concentration: 2130 nM
The estimate for compound 4 lay 2.3-fold (0.37 log units) above the measured number, and the stated range covers the measured number.
By their numbers in this assay, from the lowest: compound 4; then compounds 3 and 2 (each within the scatter of the next).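

In this assay, among these compounds, the exchange of 2,3-dimethoxyphenyl for 2,4-dimethoxyphenyl on a double-bonded chain carbon bound to a double-bonded chain carbon gives a 2.5-fold lower number from compound 3 to compound 4 (0.40 log units; beyond the scatter), the first step between compounds that differ in one place. It shows that the two dimethoxyphenyl groups are not interchangeable at this position, although their counts of atoms, donors and acceptors match, so rearranging the methoxy groups alone is enough to change the number. No measurement at hand accounts for this difference.

The compounds shown leave open how an unsubstituted phenyl, a 4-methoxyphenyl or a 2,4-dichlorophenyl would compare at this position. They also leave open whether the step would persist with a chlorophenyl in place of the other dimethoxyphenyl group on the shared core.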